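A few compounds are considered here, and "the series" means these few. Any claim that something is new, unique, unknown or untested is made for them only; others in the source may bear on it.

Measured so far:
compound 1, `Cc1cc(N2CC[C@@H](C)[C@@H](N(C)c3ncnc4[nH]ccc34)C2)n2nc(SCc3ccc([N+](=O)[O-])cc3)nc2n1`, in a functional assay on HGC-27 cells (Homo sapiens) for inhibition, read by MTT assay, with a stated time of 72 h (a higher number here means a weaker inhibitor, a lower number a stronger inhibitor), gives 29400 nM.
compound 2, `Cc1cc(N2CC[C@@H](C)[C@@H](N(C)c3ncnc4[nH]ccc34)C2)n2nc(SCc3ccc(F)c(Cl)c3)nc2n1`, in this assay gives > 100000 nM, which is a limit and not a number.

Compound 2 therefore stands at the limit of this assay, as the limit of > 100000 nM in this assay, at which 1 of the 2 values shown sits, records, so only a bound is known for it. Compound 3, `COc1ccc(CSc2nc3nc(C)cc(N4CC[C@@H](C)[C@@H](N(C)c5ncnc6[nH]ccc56)C4)n3n2)cc1`, is not yet measured. It differs from compound 2 in one place: 4-methoxyphenyl in place of 3-chloro-4-fluorophenyl on a saturated chain carbon bound to a sulfur. For the measured compounds named here, the only measured step, an at least 3.4-fold higher number from compound 1 to compound 2 (0.53 log units; beyond the scatter), alters the same chain carbon bound to a sulfur but with other groups, so it bears on the new change only loosely; it shows that the aryl group at this position can move the number by at least a modest amount. Compound 3 is expected to remain weak in this assay, with an expected step of an at least 1.6-fold lower number from compound 2 to compound 3 (0.22 log units; that floor lies within the scatter). The estimate for compound 3 is 60000 nM, within 15000 nM to 200000 nM.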

Compound 3, half-maximal inhibitory concentration: 18200 nM
Beside the measured number, compound 3's estimate is 3.3-fold (0.52 log units) above it; the range from low to high includes it.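

In this assay, 4-methoxyphenyl in place of 3-chloro-4-fluorophenyl on the saturated chain carbon bound to a sulfur gives an at least 5.4-fold lower number from compound 2 to compound 3 (0.73 log units; beyond the scatter), so the number at this position can also fall when the 3-chloro-4-fluorophenyl group leaves. Methoxy in place of nitro on an aromatic carbon gives a 1.6-fold lower number from compound 1 to compound 3 (0.21 log units; within the scatter), which shows that these two groups are not told apart here, leaving compound 2 alone apart from the other two compounds. The first of these steps can be read only as a floor: the limit of > 100000 nM in this assay, at which 1 of the 3 values shown sits.

On these data alone, how far compound 2 truly lies from the other two compounds remains unknown. As far as these compounds go, it is also open whether an amine or a carboxylic acid on this aromatic ring, or a longer chain between the sulfur and the ring, would shift the number beyond the scatter.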